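Replacing a Chlorophenyl with a Chloro-Trifluoromethylphenyl on the Core

This account rests on a few compounds, and the source may have more. Where it says the series, first, only, none or still open, it means among the compounds named here.

Compound 1 `O=C(Nc1ccc(Oc2ccnc3[nH]ccc23)c(F)c1)c1cn(-c2ccccc2)c2ccccc2c1=O`: 430 nM
Compound 2 `O=C(Nc1ccc(Oc2ccnc3[nH]ccc23)c(F)c1)c1cn(-c2ccc(Cl)cc2)c2ccccc2c1=O`: "not determined" (no result reported)

Compound 1 carries a phenyl on the aromatic nitrogen of the shared core, and in a functional assay on MCF7 cells (Homo sapiens) for inhibition, read by MTT assay, with a stated time of 72 h (a lower number here means a stronger inhibitor, a higher number a weaker inhibitor), compound 1 gives 430 nM. Compound 2 carries a 4-chlorophenyl at the same place; in this assay compound 2 gives "not determined" (no result reported), so no number stands for it and nothing can be said about how it compares with compound 1. Compound 3 `O=C(Nc1ccc(Oc2ccnc3[nH]ccc23)c(F)c1)c1cn(-c2ccc(C(F)(F)F)cc2Cl)c2ccccc2c1=O` differs from compound 2 in one place: 2-chloro-4-(trifluoromethyl)phenyl in place of 4-chlorophenyl on an aromatic nitrogen. Going by the values given here, no comparison between two measured compounds is available for this change, so its size and direction cannot be read from the data; the only anchor is the value of compound 1. The expectation for compound 3 therefore rests on compound 1 giving 430 nM, with a wide range to reflect the missing information. On that basis compound 3 is estimated in this assay at 400 nM, expected to fall between 100 nM and 1600 nM.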

Compound 3, half-maximal inhibitory concentration: 1120 nM
Beside the measured number, compound 3's estimate is 2.8-fold (0.45 log units) below it; measured number inside the range.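

In this assay, the substituent on the aromatic nitrogen of the shared core now has one readable comparison: the number rises modestly (a 2.6-fold higher number from compound 1 to compound 3 (0.42 log units; beyond the scatter)), beyond the usual scatter. Thus 2-chloro-4-(trifluoromethyl)phenyl at this place still leaves a measurable inhibitor, but a weaker one than phenyl. The step from compound 2 to compound 3 cannot be read, and nothing here offers an explanation for the rise seen with compound 3.

The compounds shown do not separate the contribution of the chlorine from that of the trifluoromethyl, since both enter together in the only readable step. On these data alone, it also remains open how this assay would respond to an amine or a carboxylic acid on the phenyl, or to a simple alkyl chain on the nitrogen in place of the phenyl.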